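Replacing a triazole with fluorophenyl: an expected solubility change

This account rests on a few compounds, and the source may have more. Where it says the series, first, only, none or still open, it means among the compounds named here.

Compound 1 `Cn1nccc1-c1cc(C(F)(F)F)ccc1[C@H]1CCOc2cc(S(=O)(=O)Nc3ccncn3)ccc21`: 1180000 nM
Compound 2 `O=S(=O)(Nc1nccs1)c1ccc2c(c1)OCC[C@H]2c1ccc(C(F)(F)F)cc1-n1ccnn1`: 154000 nM
Compound 3 `O=S(=O)(Nc1nccs1)c1ccc2c(c1)OCC[C@@H]2c1ccc(C(F)(F)F)cc1-n1ccnn1`: 171000 nM

In a physicochemical assay for solubility (on this read-out lower numbers stand for lower solubility and higher numbers for higher solubility), compound 2 gives the lowest of the three numbers, with compound 3 close by and compound 1 well apart. For the measured compounds named here, the only single-point step measured here, a 1.1-fold higher number from compound 2 to compound 3 (0.05 log units; within the scatter), rests on the fact that the fact that compounds 2 and 3 differ only in the configuration as drawn and tells nothing about exchanging a ring. Compound 4 `O=S(=O)(Nc1nccs1)c1ccc2c(c1)OCC[C@H]2c1ccc(C(F)(F)F)cc1-c1ccc(F)cc1` carries 4-fluorophenyl in place of 1H-1,2,3-triazol-1-yl on an aromatic carbon. Going by the values given here, no measured step covers such an exchange, so the expectation leans on the absence of evidence rather than on a precedent. Compound 4 is expected to give a somewhat lower number in this assay than compound 2, with the step of a 3.9-fold lower number from compound 2 to compound 4 (0.59 log units; beyond the scatter) as the estimate. Compound 4 is estimated at 40000 nM, within 10000 nM to 150000 nM.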

Compound 4, solubility: 147000 nM
Beside the measured number, compound 4's estimate is 3.7-fold (0.57 log units) below it; the range from low to high includes it.
By their numbers in this assay, from the lowest: compounds 4, 2 and 3 (each within the scatter of the next); then compound 1.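

In this assay the exchange of 1H-1,2,3-triazol-1-yl for 4-fluorophenyl on this aromatic carbon gives a 1.0-fold lower number from compound 2 to compound 4 (0.02 log units; within the scatter) and so leaves the two compounds within the scatter of each other. At this position, a six-membered aromatic ring of carbon only and a five-membered aromatic ring with 3 hetero atoms cannot be told apart on this read-out. Nothing in the available evidence bears on this result. As far as these compounds go, whether an amine or a carboxylic acid at this position would give a different number remains open. So does whether the same exchange reads alike in the configuration drawn for compound 3.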